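The compounds below may be only part of what the source reports. "The series", "measured", "known", "first", "only" and "open" are said of these compounds alone.

Three compounds of the shared core stand measured in a functional assay for inhibition of nuclear factor NF-kappa-B complex (Homo sapiens); on this read-out lower numbers stand for stronger inhibition and higher numbers for weaker inhibition. Compound 1 `COc1ccc2c(c1)OC(c1cc(OC)c(OC)c(OC)c1)C(CO)=C2` carries hydroxymethyl on the double-bonded ring carbon; in this assay compound 1 gives only the limit > 50000 nM. Compound 2 `COc1ccc2c(c1)OC(c1cc(OC)c(OC)c(OC)c1)C(C(=O)OC(C)C)=C2` carries the isopropyl ester there, and in this assay compound 2 gives 11800 nM, so that an at least 4.2-fold lower number from compound 1 to compound 2 (0.62 log units; beyond the scatter). Compound 3 `COc1ccc2c(c1)OC(c1cc(OC)c(OC)c(OC)c1)C(C(=O)N1CCCCC1)=C2` carries the piperidine amide; in this assay compound 3 gives only the limit > 50000 nM. Hence an at least 4.2-fold higher number from compound 2 to compound 3 (0.62 log units; beyond the scatter), while a step that the two limits leave unreadable from compound 1 to compound 3. Compound 3 thus sits at the weaker end of the numbers shown, sharing that position with compound 1 (the limit of > 50000 nM in this assay, at which 2 of the 3 values shown sit).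

Compound 4 `COc1ccc2c(c1)OC(c1cc(OC)c(OC)c(OC)c1)C(C=O)=C2` is the next step: hydrogen in place of piperidin-1-yl on a carbonyl carbon, read one bond further out as (piperidin-1-yl)carbonyl to formyl. Within the data shown here, no measured step removes a substituent from the carbonyl carbon in this way; the nearest are an at least 4.2-fold higher number from compound 2 to compound 3 (0.62 log units; beyond the scatter) and an at least 4.2-fold lower number from compound 1 to compound 2 (0.62 log units; beyond the scatter), both beyond the scatter. The formyl keeps the carbonyl shared with compound 2, which gives 11800 nM in this assay, and drops the amide nitrogen of compound 3. Compound 3 gives only a limit in this assay. For compound 4 a lower number is expected, about an at least 2.5-fold lower number from compound 3 to compound 4 (0.39 log units; beyond the scatter). Compound 4 is estimated at 20000 nM, within 6000 nM to 60000 nM.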

Compound 4, half-maximal inhibitory concentration: 13500 nM
Compound 4: middle estimate off by 1.5-fold (0.17 log units), on the high side; the measured number falls inside the stated range.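

In this assay, hydrogen in place of isopropoxy on a carbonyl carbon leaves the read-out within the scatter (a 1.1-fold higher number from compound 2 to compound 4 (0.06 log units; within the scatter)), so at this position the isopropoxy is not required for the level seen with the ester. The formyl group separates from both the piperidine amide (an at least 3.7-fold lower number from compound 3 to compound 4 (0.56 log units; beyond the scatter)) and the hydroxymethyl group (an at least 3.7-fold lower number from compound 1 to compound 4 (0.56 log units; beyond the scatter)), which shows that what the carbonyl carbon carries matters, and a carbonyl alone is not sufficient, with compound 3 as the case against it. Compound 1 and compound 3 remain the two compounds that give only a limit: the limit of > 50000 nM in this assay, at which 2 of the 4 values shown sit.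

Going by these compounds, whether any group on this carbonyl carbon gives a number clearly lower than those of the ester and the formyl stays open. A carboxylic acid, a methyl ketone or a dimethylamide at this place would address that.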